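A few compounds are considered here, and "the series" means these few. Any claim that something is new, unique, unknown or untested is made for them only; others in the source may bear on it.

Compound 1, `CC1=NC(C)=C(C(=O)O)C(c2ccc([N+](=O)[O-])cc2)/C1=C(\O)OC/C=C/c1ccccc1`, gives 1600 nM in a functional assay on thoracic aorta for inhibition of Voltage-gated L-type calcium channel (Rattus norvegicus); a higher number here means a weaker inhibitor, a lower number a stronger inhibitor.
Compound 2, `CC1=NC(C)=C(C(=O)O)C(c2ccccc2)/C1=C(\O)OC/C=C/c1ccccc1`, gives 9 nM in this assay.
Compound 3, `COC(=O)c1cccc(C2C(C(=O)O)=C(C)N=C(C)/C2=C(/O)OC/C=C/c2ccccc2)c1`, gives 4400 nM in this assay.

Of these three, compound 3 has the highest number, with compound 1 nearest to it and compound 2 far below both: there is a 2.8-fold higher number from compound 1 to compound 3 (0.44 log units; beyond the scatter) and a 490-fold higher number from compound 2 to compound 3 (2.69 log units; beyond the scatter), while a 180-fold lower number from compound 1 to compound 2 (2.25 log units; beyond the scatter) shows how much the nitro group costs on the shared core.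

Compound 4, `CC1=NC(C)=C(C(=O)O)C(c2cccc(C(=O)O)c2)/C1=C(\O)OC/C=C/c1ccccc1`, is compound 3 with one change: hydrogen in place of methyl on an oxygen next to a carbonyl group. Within the data shown here, the change sits on the ester that was itself introduced in the step from compound 2 to compound 3, so the only measured steps that speak to it do so indirectly. Among the measured compounds shown here, no measured pair shows an ester turned into an acid, and the core already carries a carboxylic acid in every compound. With nothing in the data pointing clearly up or down, the expectation for this assay is a small step, if any, likely within the scatter or a little higher. The estimate for compound 4 in this assay is 6000 nM, between 1500 nM and 25000 nM, meaning an expected 1.4-fold higher number from compound 3 to compound 4 (0.13 log units; within the scatter).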

Compound 4, half-maximal inhibitory concentration: > 10000 nM
Compound 4 ended at the assay's limit (the forecaster's own chance of this, stated with the estimate: 10%); middle value at least 1.6-fold (0.22 log units) from the limit.
By their numbers in this assay, from the lowest: compound 2; then compound 1; then compound 3. At a limit, above all of these: compound 4.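

In this assay compound 4 gives > 10000 nM, which is a limit of the assay and not a number: the limit of > 10000 nM in this assay, at which 1 of the 4 values shown sits.

Among these compounds, removing the methyl from the ester gives an at least 2.2-fold higher number from compound 3 to compound 4 (0.35 log units; beyond the scatter), so this change does not win back the strength lost when methoxycarbonyl replaced hydrogen; the earlier compounds showed only that the ester was costly, not how the free carboxy would compare. Carboxy in place of hydrogen gives an at least 1100-fold higher number from compound 2 to compound 4 (3.04 log units; beyond the scatter), and 3-carboxyphenyl in place of 4-nitrophenyl gives an at least 6.2-fold higher number from compound 1 to compound 4 (0.79 log units; beyond the scatter), so among the compounds shown, this group gives the weakest inhibition at this part of the molecule, while the phenyl without an added group remains far stronger.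

As far as these compounds go, how far compound 4 lies past its limit stays open, so these steps have only a lower bound on their size. Also open, from the compounds shown here alone, is whether an ethyl ester, an amide or an amine on the same phenyl would bring the number closer to that of compound 2.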